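Methoxy to Chloro: Cytotoxicity Notes on Compound 4

This account rests on a few compounds, and the source may have more. Where it says the series, first, only, none or still open, it means among the compounds named here.

The series shares one core and varies only in the substituents on a six-membered aromatic ring of carbon only. Compound 1 `COc1ccc(-c2nc(SCC(=O)c3sc(-c4ccc(Cl)cc4)nc3C)[nH]c(=O)c2C#N)cc1OC` has no result in an ADME assay on HEK293 cells (Homo sapiens) for cytotoxicity, read by MTT assay, with a stated time of 48 h; a lower number here means a stronger inhibitor, a higher number a weaker inhibitor: for compound 1 the entry reads "not determined" (no result reported). Compound 2 `COc1ccc(-c2nc(SCC(=O)c3sc(-c4ccc(Cl)cc4)nc3C)[nH]c(=O)c2C#N)cc1` likewise has no result: in this assay compound 2 reads "not determined" (no result reported). Among the compounds with values here, compound 3 `COc1cccc(-c2nc(SCC(=O)c3sc(-c4ccc(Cl)cc4)nc3C)[nH]c(=O)c2C#N)c1` is therefore the only entry with a number: in this assay compound 3 gives 77900 nM, a weak value, and with two entries blank it stands alone, so no step between measured compounds can be formed.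

Compound 4 `Cc1nc(-c2ccc(Cl)cc2)sc1C(=O)CSc1nc(-c2cccc(Cl)c2)c(C#N)c(=O)[nH]1` is the next entry to be run in this assay. It differs from compound 3 in one place: chloro in place of methoxy on an aromatic carbon.

Within the data shown here, no measured pair shows this exchange, so any expectation rests on the single value of compound 3. The step from compound 3 to compound 4 is expected to be small, within or close to the usual scatter, with a slight lean toward a lower number, a 1.3-fold lower number from compound 3 to compound 4 (0.11 log units; within the scatter). Compound 4 is estimated at 60000 nM, with a range from 25000 nM to 150000 nM, because compound 3 gives 77900 nM and nothing in the series points elsewhere. At this weak level the assay may also report only a limit rather than a number.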

Compound 4, half-maximal inhibitory concentration: 30100 nM
Estimate against measurement, compound 4: 2.0-fold (0.30 log units) above; low and high end bracket the measured number.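

In this assay, within the data shown here, the exchange of 3-methoxyphenyl for 3-chlorophenyl gives the first readable step, a 2.6-fold lower number from compound 3 to compound 4 (0.41 log units; beyond the scatter), which shows that the read-out responds to a change at this place, on an aromatic carbon meta to a large group. The step is modest but lies beyond the scatter, and it runs toward a stronger inhibitor, so a single chlorine can stand in for the methoxy group here without any loss in this read-out. Compound 4, at 30100 nM, still reads as a weak value, so the exchange shifts the number without taking the series out of the weak range, and no measurement in hand bears on the reason for the shift.

Steps to compound 1 and compound 2 cannot be read, so a single exchange at one place is all that supports any reading of this position, and it sets no trend. On these data alone, whether an amine, a carboxylic acid or a trifluoromethyl group at the same place would lower the number further, or raise it again, remains open.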